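A methyl step on compound 1 in the cytotoxicity read-out

A few compounds are considered here, and "the series" means these few. Any claim that something is new, unique, unknown or untested is made for them only; others in the source may bear on it.

Compound 1 `CCCSc1nc(Cc2c(F)cccc2Cl)cc(=O)[nH]1` is the starting point. In an ADME assay on MT4 cells (Homo sapiens) for activation, read by MTT assay (on this read-out higher numbers stand for lower toxicity in this test and lower numbers for higher toxicity in this test), compound 1 gives > 80000 nM, which is a limit and not a number. In this assay compound 2 `CCC(C)Sc1nc(Cc2c(F)cccc2Cl)cc(=O)[nH]1` gives > 76000 nM, also a limit. In this assay compound 3 `CCCSc1nc(Cc2c(F)cccc2Cl)c(C)c(=O)[nH]1` gives > 76000 nM, again a limit. Going by the values given here, the numbers so far therefore consist only of the limit of > 76000 nM in this assay, at which 2 of the 3 values shown sit, and (the limit of > 80000 nM in this assay, at which 1 of the 3 values shown sits).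

Compound 4 `CCCSc1nc(C(C)c2c(F)cccc2Cl)cc(=O)[nH]1` keeps the core of compound 1 and carries methyl in place of hydrogen on a saturated chain carbon bound to two aromatic carbons.

Two measured steps also add a methyl, though at other places. Among the compounds with values here, the first is a step that the two limits leave unreadable from compound 1 to compound 2, and the second is a step that the two limits leave unreadable from compound 1 to compound 3. Neither has a readable size, and neither gives a number in place of a limit, so they offer no measured effect to carry over. Within the data shown here, no measured step sits at the place changed in compound 4. No shift beyond the scatter is expected in this assay, in either direction, and the expected step is an at least 1.0-fold lower number from compound 1 to compound 4 (0.02 log units; that floor lies within the scatter). The estimate for compound 4 is 75000 nM, with an expected range of 30000 nM to 120000 nM.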

Compound 4, half-maximal cytotoxic concentration: > 75000 nM
Compound 4 was reported as a limit; the forecaster's own chance of this, stated with the estimate: 75%; the middle value lies on the limit itself.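

In this assay compound 4 gives > 75000 nM, which is a limit. Compound 1 gives > 80000 nM, also a limit, so the step between compound 1 and compound 4 cannot be read. The compounds shown leave open whether any of the three methyl changes on compound 1 moves the half-maximal cytotoxic concentration at all, as all four values are limits.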